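The source may report more compounds than this note shows. Statements on the series, on what has been measured and on what is new or still open speak of the compounds shown alone.

Compound 1 `CC(C)c1ccc(Nc2ccc3c(OCCCN4CCN(C)CC4)cccc3n2)cc1`: 11900 nM
Compound 2 `CN1CCN(CCCOc2cccc3nc(Nc4ccc(F)c(F)c4)ccc23)CC1`: 4670 nM
Compound 3 `CN1CCN(CCCOc2cccc3nc(Nc4cccc(Cl)c4)ccc23)CC1`: 2270 nM

These three compounds share one core and differ only in the aryl group on a nitrogen on an aromatic ring; all were tested in a functional assay on NCI-H23 cells (Homo sapiens) for inhibition, read by sulforhodamine B assay, with a stated time of 48 h; a lower number here means a stronger inhibitor of growth, a higher number a weaker inhibitor of growth. Compound 2 stands second highest of the three numbers: the step of a 2.5-fold lower number from compound 1 to compound 2 (0.41 log units; beyond the scatter) separates it from compound 1, and the step of a 2.1-fold lower number from compound 2 to compound 3 (0.31 log units; beyond the scatter) separates it from compound 3.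

Compound 4 `CN1CCN(CCCOc2cccc3nc(Nc4cc(Cl)cc(Cl)c4)ccc23)CC1` has not been measured yet. It differs from compound 2 in one place: 3,5-dichlorophenyl in place of 3,4-difluorophenyl on a nitrogen on an aromatic ring. The measured step that bears most directly on this change is a 2.1-fold lower number from compound 2 to compound 3 (0.31 log units; beyond the scatter), in which 3-chlorophenyl took the place of 3,4-difluorophenyl and the number fell modestly. Compound 4 again carries chlorine rather than fluorine, now as 3,5-dichlorophenyl, so a modest fall from compound 2 is expected, of about a 2.1-fold lower number from compound 2 to compound 4 (0.33 log units; beyond the scatter). Compound 4 is therefore estimated at 2200 nM, with a likely range from 800 nM to 6000 nM.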

Compound 4, concentration for 50% growth inhibition: 1720 nM
Compound 4: middle estimate off by 1.3-fold (0.11 log units), on the high side, within the range that was stated.
By their numbers in this assay, from the lowest: compounds 4 and 3 (each within the scatter of the next); then compound 2; then compound 1.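

On a nitrogen on an aromatic ring, 3,5-dichlorophenyl in place of 3,4-difluorophenyl gives a 2.7-fold lower number from compound 2 to compound 4 (0.43 log units; beyond the scatter) in this assay and this shows that a ring with two chloro groups, like the ring with one in compound 3, goes with a lower number than the ring with two fluoro groups. The same group in place of 4-isopropylphenyl gives a 6.9-fold lower number from compound 1 to compound 4 (0.84 log units; beyond the scatter) and this is the largest step in the set so far. A second chloro on the ring of compound 3, however, gives only a 1.3-fold lower number from compound 3 to compound 4 (0.12 log units; within the scatter) and so 3-chlorophenyl and 3,5-dichlorophenyl cannot be told apart in this assay here.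

Why these aryl groups differ remains unexplained, as no measurement bearing on the cause is available. Also open, as far as these compounds go, is how the number would respond to a nitrile, a methoxy group or a trifluoromethyl group on this same ring.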